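The source may report more compounds than this note shows. Statements on the series, on what has been measured and on what is new or still open speak of the compounds shown alone.

Measured so far:
compound 1 `COc1ccc(-c2cc(/C=C/C(=O)c3ccc(N)cc3)[nH]n2)cc1` — 86%
compound 2 `COc1cc(-c2cc(/C=C/C(=O)c3ccc(Cl)c(Cl)c3)[nH]n2)cc(OC)c1OC` — 96%

Both readings come from a functional assay on NCI-H226 cells (Homo sapiens) for cytotoxicity, read by sulforhodamine B assay, with a stated time of 48 h, tested at 1 uM; on this read-out lower numbers stand for a stronger effect and higher numbers for a weaker effect at the one concentration tested. In this assay compound 1 gives 86%, and compound 2 gives 96%. Compound 2 holds the higher of the two numbers, yet its gap to compound 1 lies within the usual scatter of such measurements, so the two readings cannot be told apart: both point to a weak effect at the single concentration tested.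

Compound 3 `COc1cc(-c2cc(/C=C/C(=O)c3ccc(F)c(F)c3)[nH]n2)cc(OC)c1OC` has not been measured yet. It differs from compound 2 at one place: 3,4-difluorophenyl in place of 3,4-dichlorophenyl on a carbonyl carbon. The rest of compound 2 is kept unchanged. Among the measured compounds shown here, no measured pair isolates this particular change, so there is no directly comparable step to lean on.

The expected step is a number 2 percentage points lower from compound 2 to compound 3 (within the scatter), that is, no change beyond the scatter in either direction. Compound 3 is estimated at 94%, with a range from 80% to 105%.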

Compound 3, a percentage reported as activity, at one concentration (the size of the read-out at that concentration, not a potency): 95%
Estimate against measurement, compound 3: 1 percentage points below, and the stated range covers the measured number.
By their numbers in this assay, from the lowest: compounds 1, 3 and 2 (each within the scatter of the next).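

In this assay, 3,4-difluorophenyl in place of 3,4-dichlorophenyl on a carbonyl carbon comes to a number 1 percentage points lower from compound 2 to compound 3 (within the scatter), so the two compounds cannot be told apart. Among the compounds shown here, this is the first pair that differs in one place, and it shows that at this position one of these two dihalophenyl groups reads like the other, with only a weak effect for both at the single concentration tested. Nothing measured here offers an explanation for this match.

As far as these compounds go, it remains open what a group of another kind would do at this place, such as a pyridine ring or a phenyl ring carrying a carboxylic acid. Compound 1 differs from compound 3 in more than one place, so it cannot show which part of the structure governs the reading.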